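The source may hold more compounds than are shown below. What is called first, only, known or untested is meant among the compounds shown, and "the series" means these compounds.

Compound 1 `CC(C)(C)/N=C(\S)NCCCCn1nc(-c2ccccc2)ccc1=O` and compound 2 `C/N=C(/NC#N)N(C)CCCCn1nc(-c2ccccc2)ccc1=O` share one core and differ only in the group on the saturated chain. In a functional assay on the whole organism with Rattus norvegicus as the target, at a dose of 100 mg/kg (on this read-out lower numbers stand for less inhibition and higher numbers for more inhibition at the one dose given (going by the name of the read-out)), compound 1 gives 33.6% and compound 2 gives 27%. Compound 2 has the lowest of the two numbers, but the step of a number 6.6 percentage points lower from compound 1 to compound 2 (within the scatter) lies within the scatter, so no order between them can be read. Compound 3 `C/N=C(\S)NCCCCn1nc(-c2ccccc2)ccc1=O` is the next member. Its change from compound 2 is a group of 5 heavy atoms (2 carbon, 2 nitrogen, 1 sulfur; no ring) in place of a group of 8 heavy atoms (4 carbon, 4 nitrogen; no ring), on a saturated chain carbon, four bonds along the chain from an aromatic nitrogen; the group that enters is a thiourea, the same kind of group that compound 1 carries, bearing a methyl in place of the tert-butyl of compound 1. For the measured compounds named here, only the step from compound 1 to compound 2 bears on this change, and it was within the scatter, so no step beyond the scatter is expected in this assay either. The estimate for compound 3 in this assay is 30% with a range from 15% to 45%, a step of a number 3 percentage points higher from compound 2 to compound 3 (within the scatter) that is expected to stay within the scatter.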

Compound 3, a percentage reported as inhibition, in the whole organism at one dose (the size of the read-out at that dose, not a potency): 87.1%
For compound 3 the middle estimate is 57.1 percentage points below the measured one, and the stated range ends below it.
By their numbers in this assay, from the lowest: compounds 2 and 1 (each within the scatter of the next); then compound 3.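

The group on the saturated chain, four bonds along the chain from an aromatic nitrogen, is not indifferent in this assay as the earlier pair suggested: the thiourea of compound 3 gives a step of a number 60.1 percentage points higher from compound 2 to compound 3 (beyond the scatter) against the cyano-bearing group. Having a thiourea there is not enough by itself, since the substituent on the double-bonded nitrogen alone accounts for a number 53.5 percentage points higher from compound 1 to compound 3 (beyond the scatter) with methyl in place of tert-butyl. The large gain therefore belongs to the methyl thiourea as a whole, not to the thiourea alone. No measurement shown here explains this rise. As far as these compounds go, whether ethyl or isopropyl on that nitrogen would side with compound 3 or with compound 1 remains open. So does whether a urea, with oxygen in place of sulfur, or a shorter chain would keep the number of compound 3.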